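The source may report more compounds than this note shows. Statements on the series, on what has been measured and on what is new or still open speak of the compounds shown alone.

Measured so far:
- compound 1, `Cc1cc(C)c(NC(=O)N(Cc2cccc(-c3nn[nH]n3)c2)C2CCCCCC2)c(C)c1`: > 1000 nM
- compound 2, `CSc1cc(C)nc(SC)c1NC(=O)N(Cc1ccccc1)Cc1cccc(-c2ccn(C)n2)c1`: 73 nM

Within the data shown here, in an assay on microsomes from intestine for inhibition of acyl-CoA:cholesterol acyltransferase (Oryctolagus cuniculus) (on this read-out higher numbers stand for weaker inhibition and lower numbers for stronger inhibition), compound 2 gives 73 nM, the only proper number among the two values shown. Compound 1, with its tetrazole and cycloheptyl arm, is reported only as a limit of the assay, > 1000 nM, and that is all that can be said of it; (the limit of > 1000 nM in this assay, at which 1 of the 2 values shown sits). Among the measured compounds shown here, compound 2 therefore stands alone as the reference point of this assay, and no step between two measured compounds is available to calibrate the next change.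

Compound 3, `CSc1cc(C)nc(SC)c1NC(=O)N(Cc1ccccc1)Cc1cccc(-c2ccnn2C)c1`, keeps the shared core of compound 2 and differs from it in one place: 1-methyl-1H-pyrazol-5-yl in place of 1-methyl-1H-pyrazol-3-yl on an aromatic carbon. The two have the same atoms, joined differently. For the measured compounds named here, with no measured step to lean on, the expectation for this assay is a small move, most likely within the usual scatter or only a little beyond it, with a slight lean toward weaker inhibition. Compound 3 is estimated at 120 nM, in the range 40 nM to 400 nM, which means an expected step of a 1.6-fold higher number from compound 2 to compound 3 (0.22 log units; within the scatter).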

Compound 3, half-maximal inhibitory concentration: 28 nM
The estimate for compound 3 lay 4.3-fold (0.63 log units) above the measured number; the measured number lies below the stated range.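

In this assay, the series now has its first readable step, a 2.6-fold lower number from compound 2 to compound 3 (0.42 log units; beyond the scatter), which places compound 3 on the side of stronger inhibition. This position, on an aromatic carbon of a six-membered aromatic ring of carbon only and meta to a large group, therefore responds to how the same atoms are joined: 1-methyl-1H-pyrazol-5-yl and 1-methyl-1H-pyrazol-3-yl have the same heavy atoms, hydrogen-bond donor and acceptor counts, and no net charge. Nothing measured here accounts for the difference between the two groups.

On these data alone, whether a 1-ethyl-1H-pyrazol-5-yl group or a carboxylic acid on the same aromatic carbon would lower the number further remains open, as does whether this step would hold with changes elsewhere on the shared core. Differing from the other compounds in more than one place, compound 1 is reported only as a limit of the assay, > 1000 nM, so its steps cannot be read.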